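A few compounds are considered here, and "the series" means these few. Any claim that something is new, unique, unknown or untested is made for them only; others in the source may bear on it.

Measured in an ADME assay on HepG2 2.2.15 cells (Homo sapiens) for cytotoxicity, read by MTT assay, with a stated time of 72 h (a higher number here means that more compound is tolerated, a lower number that less compound is tolerated), each value being a limit of the assay:
Compound 1 `O=C1OCCc2c(CO)cccc21`: > 3800000 nM
Compound 2 `CCOCC(=O)OCc1cccc2c1CCOC2=O`: > 3680000 nM
Compound 3 `O=C(OCc1cccc2c1CCOC2=O)c1cc2ccccc2[nH]1`: > 2050000 nM

Compound 1 stands only at a limit, > 3800000 nM, as do the other two compounds, so no number fixes its place. Compound 4 `O=C1OCCc2c(/C=N\O)cccc21` replaces the hydroxymethyl of compound 1 on an aromatic carbon: a group of 3 heavy atoms (1 carbon, 1 nitrogen, 1 oxygen; no ring) in place of a group of 2 heavy atoms (1 carbon, 1 oxygen; no ring), on an aromatic carbon. Among the compounds with values here, the one measured step from compound 1 is a step that the two limits leave unreadable from compound 1 to compound 2, and it offers no size to carry over. With no readable step to draw on, the expected change in this assay is an at least 1.2-fold lower number from compound 1 to compound 4 (0.10 log units; that floor lies within the scatter), which means none beyond the scatter is expected. For compound 4 the estimate is 3000000 nM, with an expected range from 1000000 nM to 6000000 nM.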

Compound 4, half-maximal cytotoxic concentration: > 4000000 nM
Compound 4: only a limit was reported; the forecaster's own chance of this, stated with the estimate: 65%; middle value at least 1.3-fold (0.12 log units) away from the limit.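

In this assay compound 4 gives > 4000000 nM, a limit of the assay. Compound 1 also stands only at a limit, so the step between compound 1 and compound 4 cannot be read. The compounds shown leave open at what concentration any of them stops being tolerated.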